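Swapping methoxy for fluoro in compound 2

The compounds below may be only part of what the source reports. "The series", "measured", "known", "first", "only" and "open" are said of these compounds alone.

Measured in a functional assay on A549 cells (Homo sapiens) for inhibition, with a stated time of 48 h, tested at 50 uM; a higher number here means more inhibition of growth at the concentration tested, a lower number less inhibition of growth:
compound 1 `COc1ccccc1/C=C/[C@@](C)(/C=C/c1ccc(O)cc1)CCC=C(C)C`: 10%
compound 2 `COc1ccc(/C=C/[C@@](C)(/C=C/c2ccc(O)cc2)CCC=C(C)C)cc1`: 40%
compound 3 `COc1ccc(/C=C/[C@@](C)(/C=C/c2ccc(O)cc2)CCC=C(C)C)cc1C=O`: 32%

Compound 2 cannot be separated from compound 3 on these numbers, since adding formyl in place of hydrogen on an aromatic carbon gives a number 8 percentage points lower from compound 2 to compound 3 (within the scatter). It stands clearly apart from compound 1, with a number 30 percentage points higher from compound 1 to compound 2 (beyond the scatter).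

The next compound to be tested is compound 4 `CC(C)=CCC[C@](C)(/C=C/c1ccc(O)cc1)/C=C/c1ccc(F)cc1`. It differs from compound 2 in one place, with fluoro in place of methoxy on an aromatic carbon, para to a large group: fluoro in place of methoxy on an aromatic carbon.

Within the data shown here, no measured step replaces the methoxy with anything else, so the evidence is only indirect. The change from 2-methoxyphenyl to 4-methoxyphenyl, a modest step, gave a number 30 percentage points higher from compound 1 to compound 2 (beyond the scatter), so the place of the methoxy can matter in this assay. The formyl addition gave a number 8 percentage points lower from compound 2 to compound 3 (within the scatter), so not every change to this 4-methoxyphenyl group shifts the number. Neither step shows what losing the methoxy does, so a step beyond the scatter is not expected, and any move is expected to be small and slightly downward. The estimated move is a number 7 percentage points lower from compound 2 to compound 4 (within the scatter). For compound 4 the expected value is 33%, with an estimated range from 15% to 55%.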

Compound 4, percent growth inhibition at one concentration: 31%
Estimate against measurement, compound 4: 2 percentage points above; the measured number falls inside the stated range.
By their numbers in this assay, from the lowest: compound 1; then compounds 4, 3 and 2 (each within the scatter of the next).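

Fluoro in place of methoxy is the first change shown that removes the methoxy itself, and in this assay it gives a number 9 percentage points lower from compound 2 to compound 4 (within the scatter). On these numbers, then, the carbon, the oxygen and the one hydrogen-bond acceptor of the methoxy can be lost without a change that can be told from the scatter. The 4-fluorophenyl compound also stands clearly apart from the 2-methoxyphenyl compound, with a number 21 percentage points higher from compound 1 to compound 4 (beyond the scatter), so compound 1 remains the only compound shown that is separated from the others, while no data here explain how these groups act on the cells.

Only methoxy and fluoro are compared at this position, so an amine or a carboxylic acid in place of them could either leave the number where it stands or move it, and the compounds shown do not tell which. Each number also comes from a single concentration, which leaves open how compound 2 and compound 4 would compare across a range of concentrations.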